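Series notes: tert-butyl to hydrogen on the aryl ring

The source may hold more compounds than are shown below. What is called first, only, known or untested is meant among the compounds shown, and "the series" means these compounds.

Three compounds share one core and differ only in the aryl group on the double-bonded chain. Compound 1 `O=C(COc1ccc(C(=O)/C=C/c2cccc(Cl)c2)cc1)N[C@H]1CCOC1=O` gives 3700 nM in a functional assay on DU-145 cells (Homo sapiens) for antiproliferative activity, read by MTT assay, with a stated time of 72 h; on this read-out lower numbers stand for stronger inhibition and higher numbers for weaker inhibition. Compound 2 `COc1ccccc1/C=C/C(=O)c1ccc(OCC(=O)N[C@H]2CCOC2=O)cc1` gives 10100 nM in this assay, and compound 3 `CC(C)(C)c1ccc(/C=C/C(=O)c2ccc(OCC(=O)N[C@H]3CCOC3=O)cc2)cc1` gives 6570 nM in this assay. Compound 3 thus holds the second highest of the three numbers; its nearest number is that of compound 2, and the furthest is that of compound 1. Both steps into compound 3, a 1.5-fold lower number from compound 2 to compound 3 (0.19 log units; within the scatter) and a 1.8-fold higher number from compound 1 to compound 3 (0.25 log units; within the scatter), lie within the scatter, whereas a 2.7-fold higher number from compound 1 to compound 2 (0.44 log units; beyond the scatter) is beyond it.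

Compound 4 `O=C(COc1ccc(C(=O)/C=C/c2ccccc2)cc1)N[C@H]1CCOC1=O` differs from compound 3 by hydrogen in place of tert-butyl on an aromatic carbon. For the measured compounds named here, no measured pair replaces a substituted aryl group with the unsubstituted one, so the closest guides remain the two steps into compound 3, both within the scatter. Across the three aryl variants the numbers span only a narrow range. A step of no more than the scatter is therefore expected, with the direction uncertain. The step of a 1.2-fold lower number from compound 3 to compound 4 (0.08 log units; within the scatter) is the expected size of this change. Compound 4 is estimated at 5500 nM, with a range of 2500 nM to 12000 nM.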

Compound 4, half-maximal inhibitory concentration: 48300 nM
For compound 4 the middle estimate is 8.8-fold (0.94 log units) below the measured one, and the stated range ends below it.
By their numbers in this assay, from the lowest: compounds 1, 3 and 2 (each within the scatter of the next, the first and the last beyond it); then compound 4.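

Compound 4 shows that the unsubstituted phenyl is not simply one more member of the aryl set in this assay: the steps are a 7.4-fold higher number from compound 3 to compound 4 (0.87 log units; beyond the scatter) and a 4.8-fold higher number from compound 2 to compound 4 (0.68 log units; beyond the scatter) and a 13-fold higher number from compound 1 to compound 4 (1.12 log units; beyond the scatter), all beyond the scatter. The narrow spread among compounds 1, 2 and 3 therefore says little about removing the substituent altogether, since among these four compounds tert-butyl, methoxy and chloro each go with a lower number than hydrogen, and no compound shown goes against this. No measurement at hand bears on the reason for this gap.

As far as these compounds go, whether a small group such as fluoro or methyl on this ring would be enough to give numbers like those of compounds 1, 2 and 3 remains open, as does whether an amine or a carboxylic acid would fit the same pattern. Each of the three substituents also appears in only one compound, so the compounds shown cannot separate the contribution of the group from that of its place on the ring.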